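The source may report more compounds than this note shows. Statements on the series, on what has been measured and on what is new or still open speak of the compounds shown alone.

Measured so far:
compound 1 `Clc1cc(Cl)cc(CO[C@H]2CCCN(Cc3ccccn3)[C@H]2c2ccccc2)c1`: > 200000 nM
compound 2 `OC[C@@H](O[C@H]1CCCN(Cc2ncc[nH]2)[C@H]1c1ccccc1)c1cc(Cl)cc(Cl)c1`: 7000 nM

In an assay on isolated protein for activation of cGMP-dependent protein kinase 1 (Homo sapiens), read by ADP-Glo, with stated times of 120 min and 40 min (a higher number here means that more compound is needed for the effect, a lower number that less compound is needed), compound 1 gives only a limit, > 200000 nM, not a number; it sits at the limit of > 200000 nM in this assay, at which 1 of the 2 values shown sits. Compound 2 gives 7000 nM in this assay. Within the data shown here, no pair of measured compounds differs in a single place, so no measured step is available. Compound 3 `Clc1cc(Cl)cc(CO[C@H]2CCCN(Cc3ccncc3)[C@H]2c2ccccc2)c1` differs from compound 1 by pyridin-4-yl in place of pyridin-2-yl on a saturated chain carbon bound to an amine nitrogen in a ring. With compound 1 known only as a limit, no step beyond the usual scatter is expected in this assay; the expected step of a number no higher from compound 1 to compound 3 (the limit leaves the size open) is essentially none. Compound 3 is therefore estimated at 200000 nM, range 50000 nM to 1000000 nM, with a further limit a real possibility.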

Compound 3, half-maximal effective concentration: > 200000 nM
Compound 3: a limit, no number (the forecaster's own chance of this, stated with the estimate: 60%); the middle value lies on the limit itself.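

No step can be read from compound 1 to compound 3, since both give only a limit, not a number, in this assay: the limit of > 200000 nM in this assay, at which 2 of the 3 values shown sit.

As far as these compounds go, whether pyridin-4-yl and pyridin-2-yl differ at all in this place remains open.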